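Adding a Trifluoromethyl Group to Three Weak Antiproliferative Amides

This account rests on a few compounds, and the source may have more. Where it says the series, first, only, none or still open, it means among the compounds named here.

Compound 1, `CC(O)(CSc1cccc(C(F)(F)F)c1)C(=O)Nc1ccc(S(F)(F)(F)(F)F)cc1`, gives 18800 nM in a functional assay on VCaP cells (Homo sapiens) for antiproliferative activity, read by propidium iodide staining, with a stated time of 96 h; a lower number here means a stronger inhibitor, a higher number a weaker inhibitor.
Compound 2, `CC(O)(CSc1cc(C(F)(F)F)cc(C(F)(F)F)c1)C(=O)Nc1ccc(S(F)(F)(F)(F)F)cc1`, gives 19400 nM in this assay.
Compound 3, `CC(O)(COc1ccc(C#N)cc1)C(=O)Nc1ccc(S(F)(F)(F)(F)F)cc1`, gives 100000 nM in this assay.

Compound 3 stands highest of the three, well beyond the scatter from both compound 1 and compound 2. The difference between the core of compound 3 and the core of compound 1 is not broken down here.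

From compound 1 to compound 2 the change is trifluoromethyl in place of hydrogen on an aromatic carbon, and it gave a 1.0-fold higher number from compound 1 to compound 2 (0.01 log units; within the scatter). Compound 4, `CC(O)(COc1ccc(C#N)cc1C(F)(F)F)C(=O)Nc1ccc(S(F)(F)(F)(F)F)cc1`, has not yet been measured; it differs from compound 3 by trifluoromethyl in place of hydrogen on an aromatic carbon. This is the same kind of change, but not the same one: in compound 2 the new group sits meta to a large group and meta to a trifluoromethyl group, whereas in compound 4 it sits ortho to a large group and meta to a cyano group.

Because the earlier step of a 1.0-fold higher number from compound 1 to compound 2 (0.01 log units; within the scatter) was within the scatter, the step to compound 4 is expected to be small as well, about a 1.1-fold lower number from compound 3 to compound 4 (0.05 log units; within the scatter). Compound 4 is therefore estimated at 90000 nM in this assay, with a range from 30000 nM to 250000 nM, the high end reflecting that compound 3 already sits at a very high value of 100000 nM.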

Compound 4, half-maximal inhibitory concentration: 100000 nM
Compound 4: middle estimate off by 1.1-fold (0.05 log units), on the low side, within the range that was stated.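

In this assay, trifluoromethyl in place of hydrogen on an aromatic carbon gave no change at the digits printed from compound 3 to compound 4 (within the scatter). Set beside the earlier step, the same kind of change reads alike on the two cores, as far as repeated measurements of this kind can tell: the same change on two cores in this assay, a 1.0-fold higher number (0.01 log units; within the scatter) from compound 1 to compound 2 and no change at the digits printed (within the scatter) from compound 3 to compound 4, 1.0-fold (0.01 log units) apart, within the scatter of two such steps. Among the compounds shown here, this does not show that trifluoromethyl leaves the number unchanged on every core, since only two cores appear, the new group stands in a different place on each, and all four compounds give high numbers, so a step on a core with a much lower number could read differently.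

The compounds shown leave open what other groups on this aromatic carbon would do, such as a chlorine atom, a methoxy group or an amine. They also leave open whether the trifluoromethyl step would stay this small on a core carrying a carboxylic acid in place of the cyano group.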